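The source may hold more compounds than are shown below. What is called first, only, known or untested is meant among the compounds shown, and "the series" means these compounds.

Measured so far in a functional assay on HUVEC cells (Homo sapiens) for inhibition, tested at 10 ug/mL; a lower number here means a weaker effect, a higher number a stronger effect of the compound at the concentration tested:
compound 1, `COc1cc(/C=C/C(=O)c2cccc(NC(=O)c3cc(Cl)cc(Cl)c3)c2)ccc1O`: 58%
compound 2, `COc1cc(/C=C/C(=O)c2cccc(NC(=O)c3ccco3)c2)ccc1O`: 100%

Among these two numbers compound 2 stands highest; its only neighbour is compound 1, and the step between them, a number 42 percentage points higher from compound 1 to compound 2 (beyond the scatter), lies beyond the scatter and is large. Compound 3, `COc1cc(/C=C/C(=O)c2cccc(NC(=O)c3ccc(Cl)c(Cl)c3)c2)ccc1O`, differs from compound 2 in one place: 3,4-dichlorophenyl in place of furan-2-yl on a carbonyl carbon. Within the data shown here, the one measured step that bears on this change is a number 42 percentage points higher from compound 1 to compound 2 (beyond the scatter), which ran the opposite way, from a dichlorophenyl to furan-2-yl. Compound 3 carries 3,4-dichlorophenyl rather than the 3,5-dichlorophenyl of compound 1, so the step is not an exact reversal, but it is the closest guide available. A drop beyond the scatter is therefore expected, of roughly the size a number 38 percentage points lower from compound 2 to compound 3 (beyond the scatter). Compound 3 is estimated to give 62% in this assay, with a range from 35% to 90%.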

Compound 3, a percentage reported as inhibition, at one concentration (the size of the read-out at that concentration, not a potency): 45%
For compound 3 the middle estimate is 17 percentage points above the measured one, and the stated range covers the measured number.
By their numbers in this assay, from the lowest: compound 3; then compound 1; then compound 2.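

In this assay the furan-2-yl group now stands above two different dichlorophenyl groups on this carbonyl carbon, and a number 55 percentage points lower from compound 2 to compound 3 (beyond the scatter) runs in the same direction as the earlier drop seen with 3,5-dichlorophenyl. The placing of the chlorines also registers at this position: a number 13 percentage points lower from compound 1 to compound 3 (beyond the scatter) separates the two dichlorophenyl groups, a modest step beside the large one that parts 3,4-dichlorophenyl from furan-2-yl. Nothing available accounts for either step.

The compounds shown leave open whether the high number is particular to furan-2-yl or would also appear with another five-membered aromatic ring on this carbonyl carbon, such as thiophen-2-yl. They also leave open how an unsubstituted phenyl or a phenyl with a single chlorine would compare with the two dichlorophenyl groups.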